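The source may hold more compounds than are shown below. What is called first, only, known or untested is meant among the compounds shown, and "the series" means these compounds.

Compound 1 `Cn1cc([N+](=O)[O-])cc1C(=O)NNC(=S)Nc1ccc([N+](=O)[O-])cc1`: 395000 nM
Compound 2 `COc1ccc(NC(=S)NNC(=O)c2cc([N+](=O)[O-])c[nH]2)cc1`: 331000 nM

Both compounds were tested in an ADME assay on Vero cells (Chlorocebus sabaeus) for cytotoxicity, read by MTT assay, with a stated time of 72 h; on this read-out lower numbers stand for stronger inhibition and higher numbers for weaker inhibition. Compound 2 gives 331000 nM and compound 1 gives 395000 nM. These two values lie within the usual scatter of each other, so the numbers do not separate the compounds.

Compound 3 `O=C(NNC(=S)Nc1ccc([N+](=O)[O-])cc1)c1cc([N+](=O)[O-])c[nH]1` has not yet been measured. It comes from compound 2 by one change: nitro in place of methoxy on an aromatic carbon, on a six-membered aromatic ring of carbon only, para to a large group (nitro in place of methoxy on an aromatic carbon).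

For the measured compounds named here, no two measured compounds differ in just one place, so the effect of this change has not been seen directly. Going by the values given here, the only guide is the closeness of the two values above, and it is a thin one. In this assay, no shift beyond the scatter is therefore expected. The estimated step is a 1.1-fold lower number from compound 2 to compound 3 (0.04 log units; within the scatter). For compound 3 the expected value is 300000 nM, with an estimated range from 130000 nM to 600000 nM.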

Compound 3, half-maximal inhibitory concentration: 529000 nM
Estimate against measurement, compound 3: 1.8-fold (0.25 log units) below, and the stated range covers the measured number.
By their numbers in this assay, from the lowest: compounds 2, 1 and 3 (each within the scatter of the next).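

In this assay, for the compounds shown here, nitro in place of methoxy on the aromatic carbon para to a large group gives a 1.6-fold higher number from compound 2 to compound 3 (0.20 log units; within the scatter) and so offers the first direct reading at this position, one that does not separate the two compounds. Hydrogen in place of methyl on the aromatic nitrogen gives a 1.3-fold higher number from compound 1 to compound 3 (0.13 log units; within the scatter) and likewise leaves the two compounds unseparated, so neither single difference has a visible effect on the number in this small set. Nothing measured here offers an explanation for either result.

At the aromatic carbon, the compounds shown carry only methoxy and nitro, so it remains open whether an amine or a carboxylic acid there would give a step beyond the scatter. On the aromatic nitrogen they carry only hydrogen and methyl, which leaves open what a longer chain would do.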